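The source may hold more compounds than are shown below. What is called first, only, known or untested is meant among the compounds shown, and "the series" means these compounds.

Compound 3 `O=c1[nH]cc(S(=O)(=O)Nc2cccc(-c3cn(-c4cccc(Cl)c4)nn3)c2)c(=O)[nH]1` carries a 3-chlorophenyl on an aromatic nitrogen of the shared core, and in a functional assay on HepG2 cells (Homo sapiens) for antiproliferative activity, read by MTT assay, with a stated time of 24 h (on this read-out lower numbers stand for stronger inhibition and higher numbers for weaker inhibition), compound 3 gives 4200 nM, the lowest number among the three measured compounds. The parent with hydrogen at that carbon, compound 1 `O=c1[nH]cc(S(=O)(=O)Nc2cccc(-c3cn(-c4ccccc4)nn3)c2)c(=O)[nH]1`, gives in this assay a value of 11200 nM, so that there is a 2.7-fold lower number from compound 1 to compound 3 (0.43 log units; beyond the scatter). Compound 2 `O=c1[nH]cc(S(=O)(=O)Nc2cccc(-c3cn(-c4cccc(F)c4)nn3)c2)c(=O)[nH]1` carries a fluoro in place of that hydrogen, and in this assay compound 2 reaches only a limit, > 20000 nM, which is the limit of > 20000 nM in this assay, at which 1 of the 3 values shown sits. From this follow an at least 4.7-fold lower number from compound 2 to compound 3 (0.67 log units; beyond the scatter) and an at least 1.7-fold higher number from compound 1 to compound 2 (0.25 log units; that floor lies within the scatter).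

Compound 4 `O=c1[nH]cc(S(=O)(=O)Nc2cccc(-c3cn(-c4ccc(Cl)cc4)nn3)c2)c(=O)[nH]1` differs from compound 3 by 4-chlorophenyl in place of 3-chlorophenyl on an aromatic nitrogen. Among the measured compounds shown here, none of the measured steps compares two positions of one substituent on that phenyl; they only exchange what stands at a single aromatic carbon. For the measured compounds named here, the chlorine itself is retained, and its introduction gave a 2.7-fold lower number from compound 1 to compound 3 (0.43 log units; beyond the scatter), so the nearest guide is compound 3 with 4200 nM, with no measured step pointing in either direction for the positional change. Compound 4 is therefore expected to give about 4500 nM in this assay, within 1500 nM to 13000 nM, an expected 1.1-fold higher number from compound 3 to compound 4 (0.03 log units; within the scatter) that stays within the scatter.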

Compound 4, half-maximal inhibitory concentration: 1960 nM
The estimate for compound 4 lay 2.3-fold (0.36 log units) above the measured number; the range from low to high includes it.
By their numbers in this assay, from the lowest: compound 4; then compound 3; then compound 1. At a limit, above all of these: compound 2.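

Moving the chlorine alone changes the result in this assay: with 4-chlorophenyl in place of 3-chlorophenyl there is a 2.1-fold lower number from compound 3 to compound 4 (0.33 log units; beyond the scatter), so the place of the chlorine on this phenyl matters and not only its presence. Measured against the unsubstituted phenyl of the parent, the 4-chlorophenyl gives a 5.7-fold lower number from compound 1 to compound 4 (0.76 log units; beyond the scatter), which is a larger step than the one seen with the 3-chlorophenyl, a 2.7-fold lower number from compound 1 to compound 3 (0.43 log units; beyond the scatter), so both chlorophenyl compounds move the same way from the parent and the 4-chlorophenyl moves further. The step from the 3-fluorophenyl is only a floor, an at least 10-fold lower number from compound 2 to compound 4 (1.00 log units; beyond the scatter), and its starting point is a limit and not a number: the limit of > 20000 nM in this assay, at which 1 of the 4 values shown sits.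

What the compounds shown leave open is whether this gain belongs to chlorine itself or would also appear with a bromo, a methoxy, an amine or a carboxylic acid in place of the chlorine of compound 4. They also do not tell why the place of the chlorine matters, or whether the same order would hold outside this assay.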